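Replacing 2-Phenylethynyl with Ethylsulfanyl

The compounds below may be only part of what the source reports. "The series", "measured", "known", "first", "only" and "open" are said of these compounds alone.

In a physicochemical assay for lipophilicity, measured as octanol-water partition (a higher number here means a more lipophilic compound, a lower number a more polar compound), compound 2 (`CCN1C(=O)c2c(nc(C#Cc3ccccc3)n2Cc2ccc(OC)cc2)N2C1=N[C@@H]1CCC[C@@H]12`) gives the lower of the two measured numbers at 5.5 and compound 1 (`CCN1C(=O)c2c(nc(C#Cc3ccccc3)n2Cc2ccc(Cl)cc2)N2C1=N[C@@H]1CCC[C@@H]12`) gives the higher one at 6.19 on the same scale. Compound 3 (`CCSc1nc2c(n1Cc1ccc(OC)cc1)C(=O)N(CC)C1=N[C@@H]3CCC[C@@H]3N12`) differs from compound 2 by ethylsulfanyl in place of 2-phenylethynyl on an aromatic carbon. For the measured compounds named here, the only measured step is a number 0.69 log units lower from compound 1 to compound 2 (beyond the scatter) for methoxy in place of chloro on an aromatic carbon. Going by the values given here, that step is modest, beyond the scatter and at another place in the molecule, so it offers only a scale and no direct precedent. The exchange in compound 3 removes a much larger group. From compound 2 at 5.5 a larger downward step is therefore expected, estimated as a number 1.30 log units lower from compound 2 to compound 3 (beyond the scatter) in this case. In this assay compound 3 is thus estimated at 4.2 with an expected range (3.6 to 4.8).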

Compound 3, partition coefficient: 4.67
Beside the measured number, compound 3's estimate is 0.47 log units below it, and the stated range covers the measured number.
By their numbers in this assay, from the lowest: compound 3; then compound 2; then compound 1.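

In this assay, this carbon of the five-membered aromatic ring, which bears 2-phenylethynyl in both earlier compounds, now proves to be a place where a change moves the number: ethylsulfanyl in place of 2-phenylethynyl gives a number 0.83 log units lower from compound 2 to compound 3 (beyond the scatter). The change takes away 8 heavy atoms, including a six-membered aromatic ring and a triple bond, and brings in 3 heavy atoms, one of them sulfur, so the loss of size and the new atom arrive together in a single step. Nothing measured here accounts for the size of this step.

The compounds shown leave open where a plain propyl chain or an amine on this carbon would fall on the same scale. They also leave open whether the exchange gives a step of like size with chloro in place of methoxy on the benzyl group.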